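The source may report more compounds than this note shows. Statements on the series, on what has been measured and on what is new or still open speak of the compounds shown alone.

Compound 1 `Cn1nccc1-c1cccc2c1CCC2c1ncc[nH]1` is known in a functional assay on CHO cells for agonist activity at Alpha-1D adrenergic receptor (Homo sapiens), read by FLIPR and calcium flux (a higher number here means that more compound is needed for the effect, a lower number that less compound is needed), only by a limit: compound 1 gives > 10000 nM, a limit of the assay rather than a number. Compound 2 `Clc1ccc2c(c1-c1ccn[nH]1)CCC2c1ncc[nH]1` likewise stops at a limit, giving > 10000 nM in this assay. Both values sit at the limit of > 10000 nM in this assay, at which 2 of the 2 values shown sit. Compound 3 `c1cc(-c2cn[nH]c2)c2c(c1)C(c1ncc[nH]1)CC2` differs from compound 1 by 1H-pyrazol-4-yl in place of 1-methyl-1H-pyrazol-5-yl on an aromatic carbon. Among the compounds with values here, no measured step between compounds exists to guide the direction, so no change beyond the scatter is expected. Compound 3 is therefore expected to give 10000 nM, between 3000 nM and 30000 nM, most likely again as a limit. The step of a number no higher from compound 1 to compound 3 (the limit leaves the size open) is expected to be none beyond the scatter.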

Compound 3, half-maximal effective concentration: 319 nM
Estimate against measurement, compound 3: 31-fold (1.50 log units) above, and the stated range ends above it.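

In this assay, 1H-pyrazol-4-yl in place of 1-methyl-1H-pyrazol-5-yl on this aromatic carbon gives an at least 31-fold lower number from compound 1 to compound 3 (1.49 log units; beyond the scatter), so the group at this place can decide whether a number is read at all. Compound 3 alone among the compounds shown has a number rather than a limit: the limit of > 10000 nM in this assay, at which 2 of the 3 values shown sit.

The change drops the methyl and shifts the point of attachment together, and the compounds shown do not separate these two. From the compounds shown here alone, how an amine or a carboxylic acid at this aromatic carbon would read also stays open.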